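Swapping the Side Ring in a Lipase Inhibitor Series

The source may hold more compounds than are shown below. What is called first, only, known or untested is meant among the compounds shown, and "the series" means these compounds.

Compound 1 `COc1coc(C(=O)CCCCCCc2ccccc2)n1`: in an assay on HEK-293T cells for inhibition of diacylglycerol lipase-alpha (Homo sapiens), read by colorimetric assay (a higher number here means a weaker inhibitor, a lower number a stronger inhibitor), compound 1 gives > 10000 nM, which is a limit of the assay.
Compound 2 `CNC(=O)c1coc(C(=O)CCCCCCc2ccccc2)n1`: compound 2 gives > 10000 nM, also a limit.
Compound 3 `O=C(CCCCCCc1ccccc1)c1nc(-c2cccs2)no1`: compound 3 gives 1950 nM.

Among the measured compounds shown here, compound 3 thus holds the only true number here; the other two values sit at the limit of > 10000 nM in this assay, at which 2 of the 3 values shown sit. The step from compound 1 to compound 2, a step that the two limits leave unreadable from compound 1 to compound 2, stays unreadable between those limits. Compound 4 `O=C(CCCCCCc1ccccc1)c1nc(-c2cccc(Cl)n2)no1` differs from compound 3 in one place: 6-chloropyridin-2-yl in place of thiophen-2-yl on an aromatic carbon. For the measured compounds named here, no measured step involves this kind of exchange, so nothing here sets its size or direction. The estimate for compound 4 therefore stays close to compound 3, at 1500 nM with a range from 400 nM to 6000 nM. The expected step of a 1.3-fold lower number from compound 3 to compound 4 (0.11 log units; within the scatter) means no change beyond the usual scatter.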

Compound 4, half-maximal inhibitory concentration: > 10000 nM
Compound 4: only a limit was reported; the forecaster's own chance of this, stated with the estimate: 15%; middle value at least 6.6-fold (0.82 log units) away from the limit.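

The aromatic carbon between two ring nitrogen atoms now has its first readable step: 6-chloropyridin-2-yl in place of thiophen-2-yl gives an at least 5.1-fold higher number from compound 3 to compound 4 (0.70 log units; beyond the scatter) in this assay. Compound 4 gives > 10000 nM, which is a limit of the assay and not a number. The side ring at this position therefore matters, and this exchange weakens inhibition beyond the usual scatter.

The compounds shown do not separate the effect of the chlorine from that of the six-membered ring. Going by these compounds, an unsubstituted phenyl or pyridin-2-yl at this position remains open, as does a chlorothiophene.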